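The source may hold more compounds than are shown below. What is called first, only, known or untested is meant among the compounds shown, and "the series" means these compounds.

Compound 1 `CCNc1ncc(C#Cc2cccc(C)c2)cn1`: "not active" (no number reported) in an assay on HEK293 cells for positive allosteric modulation of metabotropic glutamate receptor 5 (Rattus norvegicus); a higher number here means that more compound is needed for the effect, a lower number that less compound is needed
Compound 2 `CNc1ncc(C#Cc2cccc(C)c2)cn1`: 21100 nM
Compound 3 `Cc1ccc(C#Cc2cnc(C)nc2)cc1`: "not active" (no number reported) in this assay

Compound 2 is the only one of the three measured compounds that gives a number at all; the other two gave no measurable effect in this assay, so compound 2 stands alone at the top of a very short list, and its value is itself a high one, meaning a large amount of compound is needed.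

Compound 4 `CCc1ncc(C#Cc2cccc(C)c2)cn1` has not been measured. It differs from compound 2 in one place: ethyl in place of methylamino on an aromatic carbon. Among the compounds with values here, the methylamino group that leaves is the single feature setting compound 2 apart from the inactive compounds 1 and 3, and what enters is a plain two-carbon chain.

Within the data shown here, no measured pair shows a step of this kind, so the size can only be expected, not read off. Given that every measured compound without the methylamino group of compound 2 was inactive, the change from compound 2 to compound 4 is expected to weaken the effect, with a step of a 2.4-fold higher number from compound 2 to compound 4 (0.37 log units; beyond the scatter) that goes beyond the usual scatter. Compound 4 is therefore estimated at 50000 nM, with a range from 15000 nM to 200000 nM, and a real chance that only a limit, not a number, is reported.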

Compound 4, half-maximal effective concentration: "not active" (no number reported)
For compound 4 the study gives words and no number; no gap can be computed for the estimate.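

Within the data shown here, compound 4 is reported as "not active" with no number, and no step from compound 2 to compound 4 can be read. No measured evidence bears on this result. The compounds shown leave open how much the methylamino group of compound 2 matters for its effect.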